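Pyridinyl for Methoxymethyl on a Core Without Measurable Toxicity

The source may report more compounds than this note shows. Statements on the series, on what has been measured and on what is new or still open speak of the compounds shown alone.

Compound 1 `COc1ccc(-c2nc(/C=C/c3cc4ccccc4nc3OC)no2)cc1`: > 220000 nM
Compound 2 `COc1ccccc1-c1nc(/C=C/c2cc3ccccc3nc2OC)no1`: > 220000 nM
Compound 3 `COCc1nc(/C=C/c2cc3ccccc3nc2OC)no1`: > 270000 nM

In an ADME assay on HepG2 cells (Homo sapiens) for cytotoxicity, read by sulforhodamine B assay, with a stated time of 48 h (on this read-out lower numbers stand for higher toxicity in this test and higher numbers for lower toxicity in this test), compound 3 gives only a limit of the test, not a number, namely (the limit of > 270000 nM in this assay, at which 1 of the 3 values shown sits). Compound 1 likewise gives a limit, (the limit of > 220000 nM in this assay, at which 2 of the 3 values shown sit). Compound 2 gives the same limit as well. With every value a limit, the steps a step that the two limits leave unreadable from compound 1 to compound 2, a step that the two limits leave unreadable from compound 1 to compound 3 and a step that the two limits leave unreadable from compound 2 to compound 3 have no readable size; they show only that none of the three compounds reached a measurable level of toxicity in this assay.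

Compound 4 `COc1nc2ccccc2cc1/C=C/c1noc(-c2cccnc2)n1` differs from compound 3 by pyridin-3-yl in place of methoxymethyl on an aromatic carbon. The measured steps that swap the group in this same place gave no readable size, so they offer no direction for this change either. The expectation for compound 4 is therefore that it again stays out of reach of the test, with an estimated value of 250000 nM (range 100000 nM to 400000 nM). This corresponds to an expected step of an at least 1.0-fold lower number from compound 3 to compound 4 (0.03 log units; that floor lies within the scatter), with a high chance that only a limit is reported.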

Compound 4, half-maximal cytotoxic concentration: > 240000 nM
Compound 4 ended at the assay's limit; the forecaster's own chance of this, stated with the estimate: 80%; the middle value does not contradict the limit.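

Compound 4 gives > 240000 nM, which is a limit of the test and not a number. The steps to compound 4 from compound 1, compound 2 and compound 3 join limit to limit and cannot be read. The compounds shown leave open whether swapping the group in this place changes toxicity in this assay at all.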